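This account rests on a few compounds, and the source may have more. Where it says the series, first, only, none or still open, it means among the compounds named here.

Measured compounds:
compound 1 `Cc1ccc(C(C)C)c(OCc2nnc(SCC(=O)Nc3ccc([N+](=O)[O-])cc3)n2Cc2ccccc2)c1`, compound 2 `O=C(CSc1nnc(COc2ccc3ccccc3c2)n1Cc1ccccc1)Nc1ccc(Cl)cc1`, compound 3 `O=C(CSc1nnc(COc2ccc3ccccc3c2)n1Cc1ccccc1)Nc1ccc(Br)cc1`.

In a toxicity assay on MT4 cells (Homo sapiens) for cytotoxicity, read by MTT assay, with a stated time of 5 days (a lower number here means that less compound is tolerated, a higher number that more compound is tolerated), compound 1 gives 11.2 ug/mL. Compound 3 gives 58.1 ug/mL in this assay. For compound 2 the reading in this assay is a limit, >= 4.93 ug/mL, and not a number. Compound 3 thus carries the highest of the two numbers shown; the nearest is compound 1, with a lower number, a gap beyond the scatter.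

Going by the values given here, the one step between measured compounds is a step that the limit leaves unreadable from compound 2 to compound 3, and it cannot be sized, as the limit of >= 4.93 ug/mL in this assay, at which 1 of the 3 values shown sits, hides the starting value. The step now considered leads from compound 3 to the unmeasured compound 4 `O=C(CSc1nnc(COc2ccc3ccccc3c2)n1Cc1ccccc1)Nc1ccc([N+](=O)[O-])cc1`: nitro in place of bromo on an aromatic carbon. Among the compounds with values here, no measured pair shows this change alone. Compound 1 carries the same nitro group but differs from compound 3 in the ether-linked aryl as well, so the value of compound 1, 11.2 ug/mL, only hints at the direction.

On that basis compound 4 is expected to sit somewhat lower than compound 3 in this assay, the expected step being a 2.3-fold lower number from compound 3 to compound 4 (0.37 log units; beyond the scatter). The estimate for compound 4 is 25 ug/mL, with a range from 8 ug/mL to 80 ug/mL.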

Compound 4, half-maximal cytotoxic concentration: >= 116 ug/mL
Compound 4 ended at the assay's limit (the forecaster's own chance of this, stated with the estimate: 15%); middle value at least 4.6-fold (0.66 log units) from the limit.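

In this assay, the change from 4-bromophenyl to 4-nitrophenyl on the shared core gives an at least 1.9-fold higher number from compound 3 to compound 4 (0.30 log units; that floor lies within the scatter), so nitro at this place brings no lower number, although the floor of the step does not clear the scatter. With nitro held fixed, naphthalen-2-yl in place of 2-isopropyl-5-methylphenyl gives an at least 10-fold higher number from compound 1 to compound 4 (1.01 log units; beyond the scatter), so the lower number of compound 1 goes with its ether-linked aryl and not with its nitro group. The reading of compound 4 is a limit and not a number, so the full size of both steps stays open: the limit of >= 116 ug/mL in this assay, at which 1 of the 4 values shown sits.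

On these data alone, the steps from compound 2 to compound 3 and from compound 2 to compound 4 cannot be read, which leaves chloro unplaced against bromo and nitro: the limit of >= 4.93 ug/mL in this assay, at which 1 of the 4 values shown sits. Also open are how an amine or a carboxylic acid in place of nitro on this aromatic carbon would read in this assay, and whether bromo in place of nitro gives a similar reading alongside the 2-isopropyl-5-methylphenyl group.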